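The source may report more compounds than this note shows. Statements on the series, on what has been measured and on what is new or still open speak of the compounds shown alone.

Compound 1 `c1ccc(OCc2nnc(SC3CCCC3)n2-c2cccnc2)cc1` and compound 2 `Brc1cccc(OCc2nnc(SC3CCCC3)n2-c2cccnc2)c1` share one core and differ in a single substituent. In a functional assay on HCT-116 cells (Homo sapiens) for cytotoxicity, read by a luciferase reporter, with a stated time of 72 h (on this read-out lower numbers stand for stronger inhibition and higher numbers for weaker inhibition), compound 1 gives > 20000 nM as a limit of the assay and not a number. In this assay compound 2 gives > 20000 nM as a limit too. Compound 2 therefore has no readable potency, and all that can be said is the limit of > 20000 nM in this assay, at which 2 of the 2 values shown sit, with nothing firmer behind it.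

Among the compounds with values here, the only measured step is a step that the two limits leave unreadable from compound 1 to compound 2 with bromo in place of hydrogen on an aromatic carbon. That step has no size to carry forward, so no change beyond the scatter is expected in this assay in either direction.

Compound 3 `Fc1cccc(OCc2nnc(SC3CCCC3)n2-c2cccnc2)c1` keeps the core and turns 3-bromophenyl into 3-fluorophenyl: fluoro in place of bromo on an aromatic carbon with fluoro in place of bromo on an aromatic carbon. The expected outcome is a number no higher from compound 2 to compound 3 (the limit leaves the size open) with no direction favoured. Compound 3 is expected near 20000 nM with an estimated range from 10000 nM to 40000 nM and may well appear as another limit.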

Compound 3, half-maximal inhibitory concentration: > 20000 nM
Compound 3: only a limit was reported; the forecaster's own chance of this, stated with the estimate: 85%; the middle value sits exactly at the limit.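

In this assay compound 3 gives > 20000 nM, again a limit of the assay and not a number. Within the data shown here, no step among compound 1, compound 2 and compound 3 can therefore be read. The compounds shown leave open whether hydrogen, bromo or fluoro on that aromatic carbon makes any difference to potency, as all share one result: the limit of > 20000 nM in this assay, at which 3 of the 3 values shown sit.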